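The source may report more compounds than this note shows. Statements on the series, on what has been measured and on what is new or still open speak of the compounds shown alone.

Compound 1 `CN(C)C(=O)c1cnc(C(=O)CCCCCCc2ccccc2)o1` and compound 2 `COc1cnc(C(=O)CCCCCCc2ccccc2)o1` share the same core and differ only in the small group attached to one aromatic carbon. In an assay on HEK-293T cells for inhibition of diacylglycerol lipase-alpha (Homo sapiens), read by colorimetric assay (a lower number here means a stronger inhibitor, a higher number a weaker inhibitor), compound 1 reaches only a limit of the assay, > 10000 nM. In this assay compound 2 likewise reaches only a limit, > 10000 nM. The step that the two limits leave unreadable from compound 1 to compound 2 therefore cannot be sized, because of the limit of > 10000 nM in this assay, at which 2 of the 2 values shown sit. Compound 3 `CSc1cnc(C(=O)CCCCCCc2ccccc2)o1` keeps this core and alters the small group once more: methylsulfanyl in place of methoxy on an aromatic carbon. Going by the values given here, the only measured step at this position is hidden by the two limits, so it gives no readable size and no direction for this assay. Compound 3 is expected to remain at or near the limit, with an estimated step that the limit leaves unreadable from compound 2 to compound 3. For compound 3 the expected value is 20000 nM, within a range of 5000 nM to 100000 nM.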

Compound 3, half-maximal inhibitory concentration: > 10000 nM
Compound 3 ended at the assay's limit; the forecaster's own chance of this, stated with the estimate: 80%; the middle value lies beyond the limit too.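

No size can be read for the steps from compound 1 or compound 2 to compound 3, because all three compounds stop at the same limit: the limit of > 10000 nM in this assay, at which 3 of the 3 values shown sit. The compounds shown leave open which small group at this aromatic carbon, if any, would give a measurable value in this assay.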